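This account rests on a few compounds, and the source may have more. Where it says the series, first, only, none or still open, it means among the compounds named here.

Compounds measured in an ADME assay on J774 cells (Mus musculus) for cytotoxicity, read by resazurin assay, with a stated time of 72 h (on this read-out higher numbers stand for lower toxicity in this test and lower numbers for higher toxicity in this test), are given here, each entry a limit of the assay and not a number:

compound 1 `C/C(=N\Nc1nc(-c2ccccc2)cs1)c1ccc(Cl)c(Cl)c1` gives > 50000 nM (a limit)
compound 2 `C/C(=N\N=c1\scc(-c2ccccc2)n1C)c1ccc(Cl)c(Cl)c1` gives > 50000 nM (a limit)
compound 3 `C/C(=N\N=c1\scc(-c2ccccc2)n1-c1ccccc1)c1ccc(Cl)c(Cl)c1` gives > 50000 nM (a limit)

Compound 1 thus stands at a limit, in the same place as the other two compounds (the limit of > 50000 nM in this assay, at which 3 of the 3 values shown sit). Compound 4 `C/C(=N\Nc1nc(-c2ccc(Cl)cc2)cs1)c1ccc(Cl)c(Cl)c1` differs from compound 1 by one change: chloro in place of hydrogen on an aromatic carbon (chloro in place of hydrogen on an aromatic carbon, so phenyl to 4-chlorophenyl). The only measured step among these compounds is a step that the two limits leave unreadable from compound 2 to compound 3 and it concerns an aromatic nitrogen, not an aromatic carbon. Among the measured compounds shown here, no measured step covers the chloro change, so no size can be carried over. No step beyond the scatter is expected in either direction in this assay and this expectation rests only on the shared limit (the limit of > 50000 nM in this assay, at which 3 of the 3 values shown sit). The expected change is a number no higher from compound 1 to compound 4 (the limit leaves the size open) and the assay may again report only a limit. Compound 4 is estimated at 50000 nM with an expected range from 20000 nM to 100000 nM in this test.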

Compound 4, half-maximal cytotoxic concentration: > 50000 nM
Compound 4 gave a limit, no number; the forecaster's own chance of this, stated with the estimate: 65%; the middle value sits exactly at the limit.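

Compound 1 and compound 4 both stand at a limit of this assay, so no step can be read between them. The compounds shown leave open how far each lies beyond that limit, and whether chloro in place of hydrogen changes the read-out at all: the limit of > 50000 nM in this assay, at which 4 of the 4 values shown sit.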